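Resolving One Stereocentre: From Racemate to Single Enantiomer

The source may report more compounds than this note shows. Statements on the series, on what has been measured and on what is new or still open speak of the compounds shown alone.

For the measured compounds named here, compound 1, `O=[N+]([O-])c1ccc(S(=O)(=O)N2CC(n3cnc4c(Cl)nc(Cl)nc43)OCc3ccccc32)cc1`, is the only member of this small set for which a number is available. In a functional assay on MDA-MB-231 cells (Homo sapiens) for cytotoxicity, read by sulforhodamine B assay, with a stated time of 3 days (a lower number here means a stronger inhibitor, a higher number a weaker inhibitor), compound 1 gives 166 nM. Compound 2, `O=[N+]([O-])c1ccc(S(=O)(=O)N2CC(n3cnc4c(Br)ncnc43)OCc3ccccc32)cc1`, belongs to the same series, but in this assay compound 2 returned "not determined" (no result reported), so it offers no point of comparison. Compound 3, `O=[N+]([O-])c1ccc(S(=O)(=O)N2C[C@@H](n3cnc4c(Cl)nc(Cl)nc43)OCc3ccccc32)cc1`, has not yet been tested. It differs from compound 1 in this way: the two compounds have the same atoms and bonds; at least one stereo element is drawn with a configuration in one of them and without one in the other: 1 of 1 stereo elements differ; a stereocentre at a saturated ring carbon is drawn without a configuration in compound 1 and S in compound 3. Put more simply, compound 1 is drawn as a mixture of two mirror-image forms, while compound 3 is one of those forms on its own. Going by the values given here, no step between two measured compounds is available here, so the expectation rests on general experience with separating mirror-image forms: if the chosen form carries most of the activity, the number should fall by about the scatter of the method; if it carries little, the number can rise well beyond it. The middle expectation is a modest gain. Compound 3 is therefore expected to give 120 nM in this assay, within 50 nM to 500 nM, an expected step of a 1.4-fold lower number from compound 1 to compound 3 (0.14 log units; within the scatter).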

Compound 3, half-maximal inhibitory concentration: 110 nM
Estimate against measurement, compound 3: 1.1-fold (0.04 log units) above, within the range that was stated.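

In this assay, taking one mirror-image form out of the mixture gives a 1.5-fold lower number from compound 1 to compound 3 (0.18 log units; within the scatter), so the S form alone and the mixture cannot be told apart in this test. For the compounds shown here, this is the first direct comparison in the set, and it shows that the S form at this saturated ring carbon is not an inactive partner in the mixture: had it carried little of the cytotoxicity, the number for compound 3 would have been expected to rise well beyond the scatter. The comparison is a clean one, since nothing else in the structures can account for any gap between these two numbers, and the only thing that separates them is stated in one plain fact: the fact that one of compounds 1 and 3 is drawn with a defined configuration and the other without, at the place where they differ

On these data alone, how the R form would behave on its own stays open, and with it the question of whether the two forms differ at all in this test. Also open, as far as these compounds go, is what would happen to the number if an amine took the place of a chlorine atom on the shared core, or if a carboxylic acid took the place of the nitro group.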